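The source may report more compounds than this note shows. Statements on the series, on what has been measured and on what is new or still open speak of the compounds shown alone.

Compound 2 `Cc1nn(-c2ncnc3nc[nH]c23)c2c1C(NC(=O)c1ccccc1)CC(=O)N2` and compound 1 `Cc1nn(-c2ncnc3nc[nH]c23)c2c1C(C(=O)NCc1ccc(F)cc1)CC(=O)N2` share one core and differ only in the group hanging from a saturated ring carbon. In a functional assay on HEK293 cells for agonist activity at G-protein coupled receptor 39 (Homo sapiens), read by scintillation proximity assay and inositol phosphate accumulation, with a stated time of 75 min, in the presence of a further agent that is not named here (a lower number here means that less compound is needed, a higher number that more compound is needed for the effect), compound 2 gives 3 nM, the lowest of the two numbers. The carbonyl on that ring carbon is shared with compound 3, and in this assay compound 1 gives 4 nM, a gap within the scatter, so the two cannot be ranked. Compound 3 `Cc1nn(-c2ncnc3nc[nH]c23)c2c1C(C(=O)N(C)c1ccccc1)CC(=O)N2` carries methyl(phenyl)carbamoyl in place of benzamido on a saturated ring carbon. For the measured compounds named here, no measured pair shows this change, so a modest step is expected. Compound 3 is estimated at 10 nM in this assay, a step of a 3.3-fold higher number from compound 2 to compound 3 (0.52 log units; beyond the scatter), with a range from 3 nM to 40 nM.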

Compound 3, half-maximal effective concentration: 32 nM
Beside the measured number, compound 3's estimate is 3.2-fold (0.51 log units) below it, within the range that was stated.
By their numbers in this assay, from the lowest: compounds 2 and 1 (each within the scatter of the next); then compound 3.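

Swapping the group on this saturated ring carbon can change the number after all: methyl(phenyl)carbamoyl gives a clear rise in this assay against both benzamido (an 11-fold higher number from compound 2 to compound 3 (1.03 log units; beyond the scatter)) and the group of compound 1 (an 8.0-fold higher number from compound 1 to compound 3 (0.90 log units; beyond the scatter)). The new group has no hydrogen-bond donor, whereas benzamido has one, but that difference comes together with other changes in the same step. No supporting measurement explains the rise. Phenylcarbamoyl, the same group without its methyl, would separate the role of the methyl from that of the reversed amide, and its number remains open.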